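This account rests on a few compounds, and the source may have more. Where it says the series, first, only, none or still open, it means among the compounds named here.

Of the compounds shown here, three of one shared core have been tested in an assay on membranes from HeLa cells for displacement of a labelled ligand from adenosine receptor A3 (Homo sapiens), read by scintillation counting, with a stated time of 180 min, tested at 1 uM; a higher number here means more inhibition at the concentration tested (going by the name of the read-out), a lower number less inhibition. Compound 1 `CC1=C(C(=O)OC(C)(C)C)C(c2ccsc2)NC(=O)N1` gives 1%, compound 2 `CC1=C(C(=O)CC(C)C)C(c2ccsc2)NC(=O)N1` gives 14%, and compound 3 `CC1=C(C(=O)NC(C)C)C(c2ccco2)NC(=O)N1` gives 4%. On these numbers compound 3 stands second of the three, but its gaps to compound 1 and to compound 2 both lie within the scatter, so no order among them can be claimed. Compound 4 `CC1=C(C(=O)NC(C)C)C(c2ccsc2)NC(=O)N1` is not yet measured; it differs from compound 3 by thiophen-3-yl in place of furan-2-yl on a saturated ring carbon. For the measured compounds named here, the only measured step, a number 13 percentage points higher from compound 1 to compound 2 (beyond the scatter), changes the group on a carbonyl carbon, not the aromatic ring, so no measured step bears on this change. The expected step is a number 1 percentage points higher from compound 3 to compound 4 (within the scatter), within the scatter. The estimate for compound 4 is 5%, ranging from -5% to 15%.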

Compound 4, a percentage reported as inhibition, at one concentration (the size of the read-out at that concentration, not a potency): 1%
Estimate against measurement, compound 4: 4 percentage points above, within the range that was stated.
By their numbers in this assay, from the lowest: compounds 1, 4, 3 and 2 (each within the scatter of the next, the first and the last beyond it).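

In this assay, thiophen-3-yl in place of furan-2-yl on a saturated ring carbon gives only a small shift (a number 3 percentage points lower from compound 3 to compound 4 (within the scatter)), so with the isopropylcarbamoyl group kept, this ring swap has no readable effect. With thiophen-3-yl kept, isopropylamino in place of isobutyl on the carbonyl carbon gives a modest drop (a number 13 percentage points lower from compound 2 to compound 4 (beyond the scatter)), whereas isopropylamino in place of tert-butoxy gives no readable change (no change at the digits printed from compound 1 to compound 4 (within the scatter)). No supporting data explain these steps. As far as these compounds go, whether a phenyl or pyridine ring at this ring carbon would read differently remains open. So does the effect of a longer chain on the carbonyl carbon.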